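Compound 4 in the leucyl-tRNA synthetase sulfonamide series

This account rests on a few compounds, and the source may have more. Where it says the series, first, only, none or still open, it means among the compounds named here.

Three members of this series carry measured numbers. Compound 1, `CC(C)C[C@H](N)C(=O)NS(=O)(=O)c1cccc(-c2ccncc2)c1`, gives 1200 nM in an assay on isolated protein for inhibition of leucine--tRNA ligase, cytoplasmic (Homo sapiens) (a higher number here means a weaker inhibitor, a lower number a stronger inhibitor), and stands second highest of the three. Compound 2, `Cc1cc(-c2cccc(S(=O)(=O)NC(=O)[C@@H](N)CC(C)C)c2)ncn1`, gives 2000 nM; compound 3, `CC(C)C[C@H](N)C(=O)NS(=O)(=O)c1cccc(-c2ccnc(N)c2)c1`, gives 490 nM. The step of a 1.7-fold higher number from compound 1 to compound 2 (0.22 log units; within the scatter) stays within the scatter, while the step of a 2.4-fold lower number from compound 1 to compound 3 (0.39 log units; beyond the scatter) is a modest gain; the step of a 4.1-fold lower number from compound 2 to compound 3 (0.61 log units; beyond the scatter) is also modest.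

Compound 4, `Cc1cc(-c2cccc(S(=O)(=O)NC(=O)[C@@H](N)CC(C)C)c2)nc(N)n1`, combines both changes relative to compound 1: 2-amino-6-methylpyrimidin-4-yl in place of pyridin-4-yl on an aromatic carbon. Because the step of a 1.7-fold higher number from compound 1 to compound 2 (0.22 log units; within the scatter) was flat and the step of a 2.4-fold lower number from compound 1 to compound 3 (0.39 log units; beyond the scatter) a modest gain, a modest gain is expected for compound 4 as well, roughly a 1.4-fold lower number from compound 1 to compound 4 (0.15 log units; within the scatter). Compound 4 is therefore estimated at 850 nM, with a range from 400 nM to 1800 nM.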

Compound 4, half-maximal inhibitory concentration: 160 nM
Compound 4: the middle estimate sits 5.3-fold (0.73 log units) above what was measured; measured number below the stated range.
By their numbers in this assay, from the lowest: compound 4; then compound 3; then compounds 1 and 2 (each within the scatter of the next).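

Amino in place of hydrogen gives a 13-fold lower number from compound 2 to compound 4 (1.10 log units; beyond the scatter), so the gain from this change depends on the ring that carries it and does not simply add to the ring change: the same change on two cores in this assay, a 2.4-fold lower number (0.39 log units; beyond the scatter) from compound 1 to compound 3 and a 13-fold lower number (1.10 log units; beyond the scatter) from compound 2 to compound 4, 5.1-fold (0.71 log units) apart, beyond the scatter of two such steps

With the amino group present, the ring change gives a 3.1-fold lower number from compound 3 to compound 4 (0.49 log units; beyond the scatter), although the same change without it stayed within the scatter. The full replacement gives a 7.5-fold lower number from compound 1 to compound 4 (0.88 log units; beyond the scatter).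

The contributions of the methyl group and the extra ring nitrogen remain unseparated, and 2-aminopyrimidin-4-yl without the methyl would address this. On these data alone, whether the gain is specific to amino remains open, and a methylamino or hydroxyl group in its place would test that.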